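This account rests on a few compounds, and the source may have more. Where it says the series, first, only, none or still open, it means among the compounds named here.

Compound 3 `Oc1ccc(C2=NN(c3cccc(Cl)c3)C(c3cccc(Cl)c3)C2)cc1` is the stronger of the two compounds with a definite number in an assay on HEK293 cells for inhibition of protein kinase C zeta type (Homo sapiens), read by 33P incorporation, with a stated time of 40 min, in the presence of a further agent that is not named here; a lower number here means a stronger inhibitor, a higher number a weaker inhibitor: compound 3 gives 400 nM, while compound 1 `Oc1ccc(C2=NN(c3ccc(Cl)cc3)C(c3ccc(Cl)cc3)C2)c(O)c1` gives 4300 nM. Compound 2 `Oc1ccc(C2=NN(c3ccc(Cl)cc3)C(c3cccc(Cl)c3)C2)cc1` gives only a limit of this assay, < 100 nM, a situation noted as the limit of < 100 nM in this assay, at which 1 of the 3 values shown sits. Going by the values given here, the one step measured in a single place, an at least 4.0-fold higher number from compound 2 to compound 3 (0.60 log units; beyond the scatter), concerns the phenyl group on the ring nitrogen, not the saturated ring carbon. Compound 4 `Oc1ccc(C2=NN(c3cccc(Cl)c3)C(c3ccc(Cl)cc3)C2)cc1` differs from compound 3 by 4-chlorophenyl in place of 3-chlorophenyl on a saturated ring carbon. Among the compounds with values here, no measured step touches that carbon directly, so the expected change from compound 3 to compound 4 is small, a 1.3-fold lower number from compound 3 to compound 4 (0.12 log units; within the scatter), in either direction within the scatter. Compound 4 is therefore estimated at 300 nM, with a range from 100 nM to 1000 nM.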

Compound 4, half-maximal inhibitory concentration: < 100 nM
Compound 4 was reported as a limit; the forecaster's own chance of this, stated with the estimate: 15%; at least 3.0-fold (0.47 log units) between middle value and limit.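

Swapping in 4-chlorophenyl for 3-chlorophenyl on the saturated ring carbon gives an at least 4.0-fold lower number from compound 3 to compound 4 (0.60 log units; beyond the scatter) in this assay. Going by these compounds alone, until now, the only step measured in one place concerned the phenyl group on the ring nitrogen, so this is the first sign that the chlorine's place on the group at this carbon also matters. Compound 4 gives < 100 nM, which is a limit of the assay and not a number, so the full size of the step stays unknown: the limit of < 100 nM in this assay, at which 2 of the 4 values shown sit.

Still open, as far as these compounds go, is how this carbon would tolerate a group other than chlorophenyl, such as a phenyl group carrying an amine or a carboxylic acid, or a longer chain.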